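Working notes: compound 3 to compound 4

This account rests on a few compounds, and the source may have more. Where it says the series, first, only, none or still open, it means among the compounds named here.

- compound 1 `Cn1cc(-c2nc3ccccc3n2C(=O)c2ccccc2)c2cc(Br)ccc21` at 23100 nM
- compound 2 `COc1ccccc1C(=O)n1c(-c2cn(C)c3ccc(Br)cc23)nc2ccccc21` at 12800 nM
- compound 3 `COc1cccc(C(=O)n2c(-c3cn(C)c4ccc(Br)cc34)nc3ccccc32)c1` at 10800 nM

In a functional assay on A549 cells (Homo sapiens) for inhibition, read by MTT assay, with a stated time of 24 h (a higher number here means a weaker inhibitor of growth, a lower number a stronger inhibitor of growth), compound 3, at 10800 nM, cannot be separated from compound 2, and only a 2.1-fold lower number from compound 1 to compound 3 (0.33 log units; beyond the scatter) clears the scatter. Compound 4 `COc1ccc(C(=O)n2c(-c3cn(C)c4ccc(Br)cc34)nc3ccccc32)cc1` carries one change: 4-methoxyphenyl in place of 3-methoxyphenyl on a carbonyl carbon. Among the compounds with values here, the closest precedent, a 1.2-fold lower number from compound 2 to compound 3 (0.07 log units; within the scatter), also moves the methoxy group and stays small. Adding methoxy gave a 1.8-fold lower number from compound 1 to compound 2 (0.26 log units; within the scatter) and no more than the modest step above. No step beyond the scatter is therefore expected in this assay, and no direction is favoured. The expected step is a 1.1-fold higher number from compound 3 to compound 4 (0.03 log units; within the scatter) and no more. For compound 4 the estimate is 11500 nM, with an expected range of 6000 nM to 21000 nM for the measurement.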

Compound 4, concentration for 50% growth inhibition: 11300 nM
For compound 4 the middle estimate is 1.0-fold (0.01 log units) above the measured one; the range from low to high includes it.
By their numbers in this assay, from the lowest: compounds 3, 4, 2 and 1 (each within the scatter of the next, the first and the last beyond it).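

In this assay the 4-methoxyphenyl group gives a 1.0-fold higher number from compound 3 to compound 4 (0.02 log units; within the scatter) and a 1.1-fold lower number from compound 2 to compound 4 (0.05 log units; within the scatter), so the 2-, 3- and 4-methoxyphenyl groups on this carbonyl carbon all lie within the scatter of one another. Adding methoxy gives a 2.0-fold lower number from compound 1 to compound 4 (0.31 log units; beyond the scatter), a second modest step beyond the scatter alongside the 3-methoxyphenyl one, while the 2-methoxyphenyl step stays within it. No measurement at hand bears on a cause for these results.

As far as these compounds go, whether an amine or a carboxylic acid on this ring in place of methoxy would move the number further remains open, as does whether a longer chain in place of the methoxy methyl would.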